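This account rests on a few compounds, and the source may have more. Where it says the series, first, only, none or still open, it means among the compounds named here.

Measured in a functional assay on SK-BR-3 cells (Homo sapiens) for antiproliferative activity; a higher number here means a weaker inhibitor, a lower number a stronger inhibitor:
- compound 1 `CC(C)=CCc1cc(C(=O)Nc2cc3ccc(OCC4CCN(C)C4)c(C)c3oc2=O)ccc1O`: 920 nM
- compound 2 `CC(C)=CCc1cc(C(=O)Nc2cc3ccc(OCCCN4CCCC4)c(C)c3oc2=O)ccc1O`: 720 nM
- compound 3 `CCN(CC)CCCOc1ccc2cc(NC(=O)c3ccc(O)c(CC=C(C)C)c3)c(=O)oc2c1C`: 4900 nM

Compound 3 gives the highest number of the three and is the weakest of this small set. Its gaps to the other two are a 5.3-fold higher number from compound 1 to compound 3 (0.73 log units; beyond the scatter) and a 6.8-fold higher number from compound 2 to compound 3 (0.83 log units; beyond the scatter). Compounds 1 and 2 sit within the scatter of each other, at a 1.3-fold lower number from compound 1 to compound 2 (0.11 log units; within the scatter).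

The next compound is compound 4 `CC(C)=CCc1cc(C(=O)Nc2cc3ccc(OCCCN(C)C(C)C)c(C)c3oc2=O)ccc1O`. Relative to compound 3, it has isopropyl(methyl)amino in place of diethylamino on a saturated chain carbon, three bonds along the chain from an oxygen on an aromatic ring. The two structures have the same atoms, joined differently.

Among the compounds with values here, no measured step involves isopropyl(methyl)amino. The closest evidence is the change at the same place, a 6.8-fold higher number from compound 2 to compound 3 (0.83 log units; beyond the scatter), a modest step between a ring amine and an open-chain amine. Compound 4 keeps an open-chain amine, as compound 3 does, so that step is not expected to apply in full. No step beyond the scatter is expected, and the expected change is a 1.4-fold lower number from compound 3 to compound 4 (0.15 log units; within the scatter). For compound 4 the estimated value is 3500 nM, with an expected range of 1300 nM to 9000 nM.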

Compound 4, half-maximal inhibitory concentration: 570 nM
Estimate against measurement, compound 4: 6.1-fold (0.79 log units) above; the measured number lies below the stated range.
By their numbers in this assay, from the lowest: compounds 4, 2 and 1 (each within the scatter of the next); then compound 3.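

In this assay, an open-chain amine at the end of the propyl chain does not by itself go with the higher number: an 8.6-fold lower number from compound 3 to compound 4 (0.93 log units; beyond the scatter), although diethylamino and isopropyl(methyl)amino hold the same atoms, joined differently. The earlier gap between compound 2 and compound 3 therefore cannot be read simply as a ring amine against an open-chain amine, since a 1.3-fold lower number from compound 2 to compound 4 (0.10 log units; within the scatter) and a 1.6-fold lower number from compound 1 to compound 4 (0.21 log units; within the scatter), leaving compound 3 as the only one of the four that stands apart. This position thus responds to how the same atoms are arranged around the amine nitrogen, but nothing available accounts for the difference between these two groups.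

From the compounds shown here alone, compound 4 replaces both ethyl groups at once, so it remains open whether the step follows from the isopropyl group, the methyl group or the pair, and dimethylamino and ethyl(methyl)amino on the same propyl chain would help separate these. Also open, going by these compounds, is how far the result carries to other amines and chain lengths, such as piperidin-1-yl on the propyl chain or isopropyl(methyl)amino on a butyl chain.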